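Trading a Fluorobenzyl Amine for a Dipropylamine

This account rests on a few compounds, and the source may have more. Where it says the series, first, only, none or still open, it means among the compounds named here.

Measured so far:
Compound 1, `NS(=O)(=O)Oc1ccc2c(c1)CN(C(=O)c1cccc(N(Cc3ccccc3)Cc3ccco3)c1)CC2`, gives 27.5% in an assay on HEK293 cells for inhibition of Steryl-sulfatase (Homo sapiens), tested at 0.1 uM; a lower number here means a weaker effect, a higher number a stronger effect of the compound at the concentration tested.
Compound 2, `CCN(Cc1ccc(F)cc1)c1cccc(C(=O)N2CCc3ccc(OS(N)(=O)=O)cc3C2)c1`, gives 10.9% in this assay.

Both compounds share the same core and differ only in the group attached to the amide-bearing aromatic ring. On the numbers available, compound 2 stands lowest of the two: its value in this assay lies below that of compound 1 by a gap that is beyond the usual scatter of repeated measurements.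

Compound 3, `CCCN(CCC)c1cccc(C(=O)N2CCc3ccc(OS(N)(=O)=O)cc3C2)c1`, has not yet been measured. It differs from compound 2 as follows: dipropylamino in place of ethyl(4-fluorobenzyl)amino on an aromatic carbon. Among the compounds with values here, the incoming group is smaller, carries no ring and lacks the fluorine, but there is no measured pair in this set that shows how such a change moves the read-out, so nothing can be said of its direction with confidence. In this assay no step beyond the scatter is expected from compound 2 to compound 3, giving a number 1.9 percentage points lower from compound 2 to compound 3 (within the scatter) as the estimated change. For compound 3 the expected value in this assay is therefore 9%, within a range from 0% to 22%.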

Compound 3, a percentage reported as inhibition, at one concentration (the size of the read-out at that concentration, not a potency): 8.3%
Beside the measured number, compound 3's estimate is 0.7 percentage points above it, and the stated range covers the measured number.
By their numbers in this assay, from the lowest: compounds 3 and 2 (each within the scatter of the next); then compound 1.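

In this assay the exchange of ethyl(4-fluorobenzyl)amino for dipropylamino on this aromatic carbon gives a number 2.6 percentage points lower from compound 2 to compound 3 (within the scatter) and so the two compounds cannot be told apart. Within the data shown here, this is the first measured step at this position, and it shows that the six-membered aromatic ring and the fluorine of the outgoing group can both be lost, with a smaller group carrying no ring in their place, without a difference that this read-out can resolve. Nothing at hand explains why the read-out responds so little to such a large change in the group.

Both numbers are percentages at a single concentration and not potencies, so a real difference in potency between these two compounds could still lie hidden inside the scatter. As far as these compounds go, what remains open is how far this tolerance reaches at the same aromatic carbon: a plain primary amine, a carboxylic acid or a longer chain such as dibutylamino could each show whether the read-out moves at all when the group there is of a quite different kind.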